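The source may hold more compounds than are shown below. What is called first, only, known or untested is meant among the compounds shown, and "the series" means these compounds.

Compound 1 `CCCCN(C)c1cc(C(F)(F)F)ccc1CNC(=O)C(C)c1ccc(NS(C)(=O)=O)c(F)c1`: 1.2 nM
Compound 2 `CC1CCN(c2cc(C(F)(F)F)ccc2CNC(=O)C(C)c2ccc(NS(C)(=O)=O)c(F)c2)CC1`: 0.9 nM
Compound 3 `CCCCCCSc1cc(C(F)(F)F)ccc1CNC(=O)C(C)c1ccc(NS(C)(=O)=O)c(F)c1`: 1.8 nM

These three compounds share a core and differ only in the group carried on one aromatic carbon. In an assay on CHO cells for antagonist activity at transient receptor potential cation channel subfamily V member 1 (Homo sapiens), read by FLIPR (on this read-out lower numbers stand for stronger inhibition and higher numbers for weaker inhibition), compound 3 gives the highest of the three numbers, yet both its steps from the other two, a 1.5-fold higher number from compound 1 to compound 3 (0.18 log units; within the scatter) and a 2.0-fold higher number from compound 2 to compound 3 (0.30 log units; within the scatter), stay within the scatter, so the three cannot be ranked against each other.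

Compound 4 `CC(C)CCSc1cc(C(F)(F)F)ccc1CNC(=O)C(C)c1ccc(NS(C)(=O)=O)c(F)c1` is not yet measured. It differs from compound 3 by isopropyl in place of butyl on a saturated chain carbon, two bonds along the chain from a sulfur: the chain on the sulfur is kept but shortened and branched at its end. Among the measured compounds shown here, no measured step touches the chain itself; the two steps that involve compound 3 swap the whole group on the aromatic carbon, and both remained within the scatter, as did a 1.3-fold lower number from compound 1 to compound 2 (0.12 log units; within the scatter). Three quite different groups at this place gave numbers within the scatter of one another, so a modest rearrangement of the chain is expected to change little. For compound 4 the expected step is a 1.1-fold higher number from compound 3 to compound 4 (0.05 log units; within the scatter), that is, none beyond the scatter. The estimate for compound 4 in this assay is 2 nM, with a range from 0.8 nM to 5 nM.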

Compound 4, inhibition constant: 1.4 nM
The estimate for compound 4 lay 1.4-fold (0.15 log units) above the measured number, within the range that was stated.
By their numbers in this assay, from the lowest: compounds 2, 1, 4 and 3 (each within the scatter of the next).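

In this assay, among the compounds shown here, this is the first change within the sulfur chain itself rather than a swap of the whole group on the aromatic carbon, and it gives a 1.3-fold lower number from compound 3 to compound 4 (0.11 log units; within the scatter). Shortening hexylsulfanyl and branching its end to give isopentylsulfanyl therefore leaves the number within the scatter, and comparison with the two nitrogen-linked groups gives a 1.6-fold higher number from compound 2 to compound 4 (0.19 log units; within the scatter) and a 1.2-fold higher number from compound 1 to compound 4 (0.07 log units; within the scatter), so all four groups remain unranked at this place. Nothing available explains why these numbers stay so close.

On these data alone, it remains open whether a much shorter chain such as ethylsulfanyl, or a chain ending in an amine or a carboxylic acid, would also stay within the scatter. The same question applies to hexyloxy, which carries an oxygen where these chains carry sulfur.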